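Butyl in place of isopropyl on the ring nitrogen

The source may hold more compounds than are shown below. What is called first, only, known or untested is meant among the compounds shown, and "the series" means these compounds.

Compound 1: `CCCn1nc(C)c2c(C)cc(=O)oc21` — 54.3 mg/kg
Compound 2: `Cc1cc(=O)oc2c1c(C)nn2C(C)C` — > 100 mg/kg

Two compounds from this series carry a measurement in a functional assay on the whole organism with Mus musculus as the target, in the writhing test; on this read-out higher numbers stand for an effect only at larger amounts of compound and lower numbers for an effect already at smaller amounts. Compound 1 `CCCn1nc(C)c2c(C)cc(=O)oc21` gives 54.3 mg/kg. Compound 2 `Cc1cc(=O)oc2c1c(C)nn2C(C)C` reaches only a limit of the assay, > 100 mg/kg, so its position on this read-out is known merely as a range (the limit of > 100 mg/kg in this assay, at which 1 of the 2 values shown sits). Within the data shown here, the step of an at least 1.8-fold higher number from compound 1 to compound 2 (0.26 log units; that floor lies within the scatter) is the single measured change, and it ends at that limit.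

Compound 3 `CCCCn1nc(C)c2c(C)cc(=O)oc21` differs from compound 2 by butyl in place of isopropyl on an aromatic nitrogen. Among the measured compounds shown here, compound 1, with propyl, gives the one definite number; compound 2, with isopropyl, ended at the limit. A butyl chain on the same nitrogen is the change to be judged.

For the measured compounds named here, the author expects compound 3 to lie near the value of compound 1, because 54.3 mg/kg is the only firm number in this assay. For compound 3 the estimate is 70 mg/kg, within 30 mg/kg to 160 mg/kg. This estimate implies an expected step of an at least 1.4-fold lower number from compound 2 to compound 3 (0.15 log units; that floor lies within the scatter), with a real chance that compound 3 again reaches only the limit.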

Compound 3, dose for half-maximal effect: > 100 mg/kg
Compound 3: a limit, no number (the forecaster's own chance of this, stated with the estimate: 35%); middle value at least 1.4-fold (0.15 log units) away from the limit.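

In this assay compound 3 gives > 100 mg/kg as a limit and not a number, so at this aromatic nitrogen butyl, like isopropyl, yields no definite value. Against the propyl of compound 1, the butyl chain gives an at least 1.8-fold higher number from compound 1 to compound 3 (0.26 log units; that floor lies within the scatter) and leaves open how far compound 3 really stands from compound 1, since that floor lies within the scatter. The step between compound 2 and compound 3 cannot be read because both stand at the limit: the limit of > 100 mg/kg in this assay, at which 2 of the 3 values shown sit.

Compound 1 remains the only definite number, so the compounds shown cannot tell whether propyl is truly preferred over butyl or isopropyl on this nitrogen. Going by these compounds, whether an ethyl group or a chain ending in an amine would give a definite value at this position also stays open.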